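A few compounds are considered here, and "the series" means these few. Any claim that something is new, unique, unknown or untested is made for them only; others in the source may bear on it.

Measured so far in an in vitro ADME assay on microsomes (Mus musculus) for metabolic stability; on this read-out lower numbers stand for a shorter-lived compound and higher numbers for a longer-lived compound:
- compound 1 `O=C(Nc1ccc(-c2nc(N3CC4CCC(C3)O4)c3cnn(C4CCC5(CC4)OCCO5)c3n2)cc1)NC1CC1`, which gives 0.417 h.
- compound 2 `O=C(Nc1ccc(-c2nc(N3CC4CCC(C3)O4)c3cnn(C4CCC5(CC4)OCCO5)c3n2)cc1)Nc1cccnc1`, which reaches only > 0.5 h; that figure is the edge of what the test reports, not a measured number.

For the measured compounds named here, compound 2 thus stands at the upper boundary of the reported range, and the single measured step leading to it, an at least 1.1-fold higher number from compound 1 to compound 2 (0.07 log units; that floor lies within the scatter), is set by the limit of > 0.5 h in this assay, at which 1 of the 2 values shown sits, rather than by two plain numbers. Compound 3 `CCNC(=O)Nc1ccc(-c2nc(N3CC4CCC(C3)O4)c3cnn(C4CCC5(CC4)OCCO5)c3n2)cc1` differs from compound 2 by ethyl in place of pyridin-3-yl on an amide-type nitrogen. The measured step swapped cyclopropyl for pyridin-3-yl on the same amide-type nitrogen; the present change removes pyridin-3-yl again and puts ethyl in its place, so compound 1 is the closest measured point of comparison, and its value stays within the usual scatter of anything the limit allows. On that footing the expected step in this assay is an at least 1.1-fold lower number from compound 2 to compound 3 (0.07 log units; that floor lies within the scatter), with compound 3 expected to settle near the number seen for compound 1. Compound 3 is estimated at 0.42 h, with a likely range from 0.2 h to 0.8 h.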

Compound 3, half-life: 0.45 h
Estimate against measurement, compound 3: 1.1-fold (0.03 log units) below; low and high end bracket the measured number.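

In this assay, ethyl in place of cyclopropyl on the amide-type nitrogen gives a 1.1-fold higher number from compound 1 to compound 3 (0.03 log units; within the scatter), so this direct comparison cannot tell the two groups apart, and a ring at this spot is not needed to reach this level of half-life. The comparison with the aromatic group, ethyl in place of pyridin-3-yl on the same nitrogen, gives an at least 1.1-fold lower number from compound 2 to compound 3 (0.04 log units; that floor lies within the scatter), and that figure is only a floor that does not rise beyond the scatter, so it does not establish a real difference between these two groups. The full size of this second step stays hidden because compound 2 carries a limit rather than a plain number: the limit of > 0.5 h in this assay, at which 1 of the 3 values shown sits.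

From the compounds shown here alone, whether pyridin-3-yl truly gives a longer half-life than ethyl or cyclopropyl therefore remains open, as does how far compound 2 lies past the limit. Also open, going by these compounds, is how a phenyl ring, a longer chain such as butyl, or a chain ending in an amine or a carboxylic acid on this nitrogen would behave in this assay.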